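A Hydroxymethyl Added to the Pyridinyl Arm

The compounds below may be only part of what the source reports. "The series", "measured", "known", "first", "only" and "open" are said of these compounds alone.

Compound 1, `O=C(NO)c1cc2ccn(Cc3ccc(F)cc3)c2cn1`, in an ADME assay on CEM-SS cells (Homo sapiens) for cytotoxicity, read by XTT assay (a lower number here means that less compound is tolerated, a higher number that more compound is tolerated), gives 159000 nM.
Compound 2, `O=C(NO)c1cc2ccn(Cc3ccccn3)c2cn1`, in this assay gives only the limit > 10000 nM.

The two measured compounds share one core and differ only in the group on the saturated chain carbon bound to the aromatic nitrogen. The step that the limit leaves unreadable from compound 1 to compound 2 cannot be read because of the limit of > 10000 nM in this assay, at which 1 of the 2 values shown sits. Compound 2 therefore stands at a limit in this assay, and where its true value lies is not known from these numbers.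

Compound 3, `O=C(NO)c1cc2ccn(Cc3ncccc3CO)c2cn1`, follows from compound 2 by hydroxymethyl in place of hydrogen on an aromatic carbon. For the measured compounds named here, no measured step bears directly on this change: the only step on record is unreadable and concerns a different place in the molecule. Because compound 2 is known only as the limit > 10000 nM the ground for any expectation is thin. For compound 3 a step that the limit leaves unreadable from compound 2 to compound 3 is expected, with no direction beyond the scatter that the data could support. Compound 3 is therefore estimated at 60000 nM in this assay, with a range from 10000 nM to 300000 nM.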

Compound 3, half-maximal cytotoxic concentration: > 10000 nM
Compound 3: only a limit was reported; the forecaster's own chance of this, stated with the estimate: 50%; the middle value is on the limit's open side.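

Compound 3, like compound 2, is reported only as a limit, so no new step can be read between the two: the limit of > 10000 nM in this assay, at which 2 of the 3 values shown sit.

The compounds shown leave open where the true values of compound 2 and compound 3 lie in this assay, and whether hydroxymethyl in place of hydrogen on an aromatic carbon shifts the read-out at all.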